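This account rests on a few compounds, and the source may have more. Where it says the series, first, only, none or still open, it means among the compounds named here.

Compound 2 `CCN1CCN(C[C@H]2CN(c3ccc(-n4cc(-c5ccccn5)cn4)c(F)c3)C(=O)O2)CC1` gives the highest number of the three compounds measured in a physicochemical assay for solubility, read by HPLC, with a stated time of 24 h (a lower number here means a less soluble compound, a higher number a more soluble compound), at 706000 nM. Compound 1 `CN(CCC#N)C[C@H]1CN(c2ccc(-n3cc(-c4ccccn4)cn3)c(F)c2)C(=O)O1` gives 64500 nM in this assay, and compound 3 `COC(=O)CC1CCN(C[C@H]2CN(c3ccc(-n4cc(-c5ccccn5)cn4)c(F)c3)C(=O)O2)CC1` gives 92100 nM. The step of an 11-fold higher number from compound 1 to compound 2 (1.04 log units; beyond the scatter) and the step of a 7.7-fold lower number from compound 2 to compound 3 (0.88 log units; beyond the scatter) both set compound 2 well apart from the other two, while compound 1 and compound 3 are separated only by a 1.4-fold higher number from compound 1 to compound 3 (0.15 log units; within the scatter), which is within the scatter. Compound 4 `O=C1CNC(=O)N1C[C@H]1CN(c2ccc(-n3cc(-c4ccccn4)cn3)c(F)c2)C(=O)O1` is reached from compound 2 by the change (2,5-dioxoimidazolidin-1-yl in place of 4-ethylpiperazin-1-yl on a saturated chain carbon bound to a saturated ring carbon). Within the data shown here, the two replacements of the 4-ethylpiperazin-1-yl group of compound 2 that have already been measured at this position each gave a clearly lower number, so a step of comparable size in the same direction is expected here, although the change to compound 4 itself has no measured counterpart and the data offer no closer comparison. In this assay compound 4 is therefore expected to give 45000 nM, within a range of 12000 nM to 160000 nM. That estimate would mean an expected step of a 16-fold lower number from compound 2 to compound 4 (1.20 log units; beyond the scatter).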

Compound 4, solubility: 1630000 nM
Compound 4: middle estimate off by 36-fold (1.56 log units), on the low side; measured number above the stated range.
By their numbers in this assay, from the lowest: compounds 1 and 3 (each within the scatter of the next); then compound 2; then compound 4.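

Among these compounds, at this position, on a saturated chain carbon bound to a saturated ring carbon, 2,5-dioxoimidazolidin-1-yl is the first replacement of 4-ethylpiperazin-1-yl to give a higher number in this assay, with a 2.3-fold higher number from compound 2 to compound 4 (0.36 log units; beyond the scatter), whereas the replacements in compound 1 and compound 3 both gave a lower number. The new group also stands well clear of those two, with an 18-fold higher number from compound 3 to compound 4 (1.25 log units; beyond the scatter) and a 25-fold higher number from compound 1 to compound 4 (1.40 log units; beyond the scatter), so the highest number in the set no longer belongs to a 4-ethylpiperazin-1-yl compound. No supporting measurement accounts for this rise.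

As far as these compounds go, what a methyl group in place of the amide hydrogen of the 2,5-dioxoimidazolidin-1-yl ring would do to the number remains open. So does the outcome for a carboxylic acid or a primary amine carried on a longer chain at this position.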